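This account rests on a few compounds, and the source may have more. Where it says the series, first, only, none or still open, it means among the compounds named here.

Series notes, three members of the shared core measured so far.

Compound 3 `Cc1ccc(C2SCC(=O)N2CCN2CCCCC2)cc1` gives 13% in an ADME assay on Vero cells (Chlorocebus sabaeus) for cytotoxicity, read by neutral red uptake, tested at 1575 ug/mL; a lower number here means a stronger effect, a higher number a weaker effect of the compound at the concentration tested. On that number compound 3 stands level with compound 2 `O=C1CSC(c2cccc(O)c2)N1CCN1CCCCC1`, which gives 13% in this assay, the two together being the highest of the three readings; compound 1 `COc1ccc(C2SCC(=O)N2CCN2CCCCC2)cc1` sits furthest off, giving 11%. Neither separation is beyond the scatter.

The next member, compound 4 `O=C1CSC(c2ccc(F)cc2)N1CCN1CCCCC1`, differs from compound 3 in one place: fluoro in place of methyl on an aromatic carbon. Cut one bond further out, the change reads 4-methylphenyl to 4-fluorophenyl.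

For the measured compounds named here, two measured steps touch the same aryl substituent. The step of a number 2 percentage points higher from compound 1 to compound 3 (within the scatter) and the step of no change at the digits printed from compound 2 to compound 3 (within the scatter) both stayed within the scatter, so changes of this kind on the aryl ring have so far left this assay flat. Going by the values given here, no step exchanging methyl for fluoro has been measured, so the expectation rests on those two steps only.

On that basis the step of a number 1 percentage points lower from compound 3 to compound 4 (within the scatter) is expected to lie within the scatter, with no direction favoured. Compound 4 is therefore estimated at 12%, within a range of 3% to 23% in this assay.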

Compound 4, a percentage reported as activity, at one concentration (the size of the read-out at that concentration, not a potency): 14%
For compound 4 the middle estimate is 2 percentage points below the measured one, within the range that was stated.
By their numbers in this assay, from the lowest: compounds 1, 2, 3 and 4 (each within the scatter of the next).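

Fluoro, on an aromatic carbon para to a large group, is the first halogen at this place, and in this assay the exchange for methyl gives a number 1 percentage points higher from compound 3 to compound 4 (within the scatter) and does not separate the two compounds. The two other exchanges ending in 4-fluorophenyl agree, with a number 1 percentage points higher from compound 2 to compound 4 (within the scatter) and a number 3 percentage points higher from compound 1 to compound 4 (within the scatter) as the printed steps, so every listed step among these four compounds now stays within the scatter, with none going against it. Nothing available explains this flat result.

Going by these compounds, whether a carboxylic acid or an amine on the aromatic ring would shift this read-out remains open. On these data alone, all four compounds also share the rest of the structure, so the effect of any change outside the aryl substituent is unknown.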